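Removing the methoxy from compound 2

The source may report more compounds than this note shows. Statements on the series, on what has been measured and on what is new or still open speak of the compounds shown alone.

Compound 1, `CCCCOC1(c2ccc(Br)cc2)SC=C(C)n2c1noc2=O`, gives 82000 nM in a functional assay on A2780 cells (Homo sapiens) for antiproliferative activity, read by MTT assay, with a stated time of 3 days; on this read-out higher numbers stand for weaker inhibition and lower numbers for stronger inhibition.
Compound 2, `COc1ccc(C2(O)SC=C(C)n3c2noc3=O)cc1`, gives only a limit in this assay, > 100000 nM.
Compound 3, `COC1(c2ccc(Br)cc2)SC=C(C)n2c1noc2=O`, gives 148000 nM in this assay.

Of the three measured compounds, only compound 1 and compound 3 carry a number. Within the data shown here, the single measured step between them, a 1.8-fold higher number from compound 1 to compound 3 (0.26 log units; within the scatter), concerns hydrogen in place of propyl on a saturated chain carbon bound to an oxygen on a saturated carbon, and it stays within the scatter. Compound 2 stands at the limit of > 100000 nM in this assay, at which 1 of the 3 values shown sits; this is a limit and not a number, so its place among the measured compounds cannot be fixed more closely than that.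

Compound 4, `CC1=CSC(O)(c2ccccc2)c2noc(=O)n21`, differs from compound 2 by hydrogen in place of methoxy on an aromatic carbon. Among the measured compounds shown here, no measured step touches this part of the structure: the one step in hand, from compound 1 to compound 3, sits on the saturated carbon and was within the scatter. With nothing pointing in either direction, the expected step is none beyond the scatter, a step that the limit leaves unreadable from compound 2 to compound 4. Compound 4 is therefore expected near 120000 nM in this assay, in a range from 50000 nM to 300000 nM, and it may well be reported again only as a limit.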

Compound 4, half-maximal inhibitory concentration: > 100000 nM
Compound 4: only a limit was reported; the forecaster's own chance of this, stated with the estimate: 60%; the middle value is on the limit's open side.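

Compound 2 and compound 4 are both reported only as limits in this assay, so no step can be read between them: the limit of > 100000 nM in this assay, at which 2 of the 4 values shown sit.

The compounds shown leave open whether hydrogen in place of methoxy on an aromatic carbon changes the antiproliferative read-out at all, as neither compound carries a number.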